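A few compounds are considered here, and "the series" means these few. Any claim that something is new, unique, unknown or untested is made for them only; others in the source may bear on it.

Working notes on the series. Compound 1 `CCc1nc(N)c2nn(-c3ccccc3)cc2n1` is the reference point; in an assay on CHO cells for displacement of a labelled ligand from adenosine receptor A3 (Homo sapiens), read by scintillation counting, tested at 1 uM (on this read-out lower numbers stand for less inhibition and higher numbers for more inhibition at the one concentration tested (going by the name of the read-out)), compound 1 gives 38%. Compound 2 `Nc1nc(Cc2ccc(O)cc2)nc2cn(-c3ccccc3)nc12` carries 4-hydroxyphenyl in place of methyl on a saturated chain carbon bound to an aromatic carbon, and in this assay compound 2 gives 20%. That single step, a number 18 percentage points lower from compound 1 to compound 2 (beyond the scatter), is the only one so far, and it puts compound 1 at the higher of the two numbers, with compound 2 as its nearest neighbour.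

Compound 3 `Nc1nc(/C=C/c2ccccc2)nc2cn(-c3ccccc3)nc12` is not yet measured. It differs from compound 1 as follows: 2-phenylethenyl in place of ethyl on an aromatic carbon. The step from compound 1 to compound 2 is the only one that bears on this change, since it too places an aromatic ring on the same part of the shared core, and it lowered the read-out. On that basis a drop is expected for compound 3 in this assay, of about the same size, a number 13 percentage points lower from compound 1 to compound 3 (beyond the scatter). For compound 3 the estimate is 25%, with a range from 5% to 45%.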

Compound 3, a percentage reported as inhibition, at one concentration (the size of the read-out at that concentration, not a potency): 25%
For compound 3 middle estimate and measured number coincide at the digits printed, within the range that was stated.
By their numbers in this assay, from the lowest: compounds 2 and 3 (each within the scatter of the next); then compound 1.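

At this position, on an aromatic carbon between two ring nitrogen atoms, 2-phenylethenyl in place of ethyl gives a number 13 percentage points lower from compound 1 to compound 3 (beyond the scatter) in this assay, so a second group carrying a six-membered aromatic ring also stands lower than the ethyl group of compound 1. Of the two aromatic groups, the swap of 4-hydroxybenzyl for 2-phenylethenyl gives a number 5 percentage points higher from compound 2 to compound 3 (within the scatter), so these two groups cannot be told apart in this assay, although 2-phenylethenyl carries a double bond outside aromatic rings and no hydroxyl group. No measurement at hand offers an explanation for these numbers.

The compounds shown leave open whether the lower numbers follow the aromatic ring itself or simply a larger group, and a butyl chain or a cyclohexylmethyl group on the same carbon would bear on that question. Also open, as far as these compounds go, is how an amine or a carboxylic acid at this position would read, and whether any group there could stand above compound 1 at 38%.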